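A few compounds are considered here, and "the series" means these few. Any claim that something is new, unique, unknown or untested is made for them only; others in the source may bear on it.

Three compounds share one core. Compound 1 `COc1ccc(-c2cc(/C=C/C(=O)c3ccc(N)cc3)[nH]n2)cc1` carries a single methoxy group on its outer ring, compound 2 `COc1cc(-c2cc(/C=C/C(=O)c3ccc(N)cc3)[nH]n2)cc(OC)c1OC` carries three, and compound 3 `COc1cc(-c2cc(/C=C/C(=O)c3ccc(F)c(F)c3)[nH]n2)cc(OC)c1OC` keeps the three methoxy groups but changes the ring on the carbonyl. In a functional assay on TK-10 cells (Homo sapiens) for cytotoxicity, read by sulforhodamine B assay, with a stated time of 48 h, tested at 100 uM (a lower number here means a stronger effect, a higher number a weaker effect of the compound at the concentration tested), compound 1 gives -91%, compound 2 gives -81% and compound 3 gives -37%; compound 2 thus sits second highest, close to compound 1 within the scatter and far from compound 3. The only shown step, a number 44 percentage points higher from compound 2 to compound 3 (beyond the scatter), concerns the carbonyl-bound ring, not the methoxy pattern. Compound 4 `COc1ccc(-c2cc(/C=C/C(=O)c3ccc(N)cc3)[nH]n2)cc1OC` arises from compound 2 by hydrogen in place of methoxy on an aromatic carbon. Since compounds 1 and 2 lie within the scatter of each other, no step beyond the scatter is expected: a number 5 percentage points lower from compound 2 to compound 4 (within the scatter). Compound 4 is therefore estimated at -86%, between -100% and -70%.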

Compound 4, a percentage reported as activity, at one concentration (the size of the read-out at that concentration, not a potency): -98%
The estimate for compound 4 lay 12 percentage points above the measured number; low and high end bracket the measured number.
By their numbers in this assay, from the lowest: compounds 4, 1 and 2 (each within the scatter of the next, the first and the last beyond it); then compound 3.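

In this assay hydrogen in place of methoxy, ortho to a methoxy group, gives a number 17 percentage points lower from compound 2 to compound 4 (beyond the scatter) and is the first shown change on the methoxy-bearing ring with a step beyond the scatter. Methoxy in place of hydrogen on that ring gives a number 7 percentage points lower from compound 1 to compound 4 (within the scatter) and is not a clear change, so the two methoxy changes do not count alike. Nothing available explains this difference. Going by these compounds, whether an ethoxy or hydroxy group at this place would behave like hydrogen or like methoxy stays open, as does whether the same change holds with the 3,4-difluorophenyl ring on the carbonyl.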